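Aryloxy swap on a diaminoquinoxaline growth inhibitor

This account rests on a few compounds, and the source may have more. Where it says the series, first, only, none or still open, it means among the compounds named here.

Measured so far:
- compound 1, `Nc1cc(N)c2nc(-c3ccccc3)c(Oc3ccc(Cl)c(Cl)c3)nc2c1`: 18200 nM
- compound 2, `CCOC(=O)[C@H](CCC(=O)O)NC(=O)c1ccc(Oc2nc3cc(N)cc(N)c3nc2-c2ccccc2)cc1`: < 100000 nM

Among the measured compounds shown here, compound 1 is the only compound of the pair with a number in a functional assay on A549 cells (Homo sapiens) for inhibition, read by sulforhodamine B assay, with a stated time of 48 h; a higher number here means a weaker inhibitor of growth, a lower number a stronger inhibitor of growth; there it gives 18200 nM. Compound 2 reaches only the limit of this assay, < 100000 nM, which is a limit and not a number, and so sets no scale against compound 1 (the limit of < 100000 nM in this assay, at which 1 of the 2 values shown sits). For the measured compounds named here, no step between two measured compounds is available.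

Compound 3, `Nc1cc(N)c2nc(-c3ccccc3)c(Oc3ccc(F)cc3)nc2c1`, keeps the shared core of compound 1 and differs in one place: 4-fluorophenyl in place of 3,4-dichlorophenyl on an oxygen on an aromatic ring. The two aryloxy groups, 3,4-dichlorophenoxy against 4-fluorophenoxy, differ in the count and kind of halogen and nothing else. Going by the values given here, with no measured step to lean on, the expectation for the step from compound 1 to compound 3 is a modest loss of growth inhibition, expected as a 1.6-fold higher number from compound 1 to compound 3 (0.22 log units; within the scatter), though a change within the scatter cannot be excluded. Compound 3 is accordingly expected to give about 30000 nM in this assay, within 8000 nM to 120000 nM, with some chance of only a limit being returned.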

Compound 3, concentration for 50% growth inhibition: 24000 nM
Estimate against measurement, compound 3: 1.3-fold (0.10 log units) above, and the stated range covers the measured number.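

In this assay the aryloxy position now carries its first readable step: a 1.3-fold higher number from compound 1 to compound 3 (0.12 log units; within the scatter) with 4-fluorophenyl in place of 3,4-dichlorophenyl on an oxygen on an aromatic ring. Compound 1 and compound 3 therefore cannot be told apart in this assay, so going from 3,4-dichlorophenoxy to 4-fluorophenoxy, a change in the count and kind of halogen, gives no readable change in growth inhibition. On this single pair the position accepts that halogen swap, and nothing at hand accounts for the result.

Among the compounds shown here, for compound 2 the reading < 100000 nM is a limit and not a number, so no step to its aryloxy group can be read. Still open, on these data alone, is whether this position responds at all to anything other than a halogen on the phenyl ring, such as a plain phenyl, a methoxy group, an amine or a carboxylic acid, and whether any such group would move the number beyond the scatter.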